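The source may hold more compounds than are shown below. What is called first, only, known or untested is meant among the compounds shown, and "the series" means these compounds.

Compound 3 `CCCCCCCCCCCCCCNC(=O)[C@H](CO)/N=C/c1ccccc1Cl` gives the lowest of the three numbers measured in a functional assay on cells (Homo sapiens) for cytotoxicity, read by MTT assay, with a stated time of 24 h (a lower number here means a stronger inhibitor, a higher number a weaker inhibitor), with 10300 nM; compound 1 `CCCCCCCCCCCCCCNC(=O)[C@H](CO)/N=C/c1ccccc1OC` at 12500 nM lies within the scatter of it, while compound 2 `CCCCCCCCCCCCCCNC(=O)[C@H](CO)/N=C/c1ccc(Cl)cc1` at 27500 nM stands higher. Compound 4 `CCCCCCCCCCCCCCNC(=O)[C@H](CO)/N=C/c1ccc(C)cc1` alters the aromatic group: 4-methylphenyl in place of 2-chlorophenyl on a carbon with a double bond to nitrogen. For the measured compounds named here, two measured steps bear on this. The step of a 2.7-fold lower number from compound 2 to compound 3 (0.43 log units; beyond the scatter) shows a modest fall when the aromatic group changed, and a 2.2-fold higher number from compound 1 to compound 2 (0.34 log units; beyond the scatter) shows a modest rise in the reverse direction. Both suggest that a 4-substituted aromatic group, as in compound 2 and compound 4, carries a modestly higher number than the 2-chlorophenyl of compound 3. A modest rise is therefore expected for compound 4, a 2.4-fold higher number from compound 3 to compound 4 (0.39 log units; beyond the scatter). Compound 4 is estimated at 25000 nM, within 12000 nM to 50000 nM.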

Compound 4, half-maximal inhibitory concentration: 102000 nM
The estimate for compound 4 lay 4.1-fold (0.61 log units) below the measured number, and the stated range ends below it.
By their numbers in this assay, from the lowest: compounds 3 and 1 (each within the scatter of the next); then compound 2; then compound 4.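

In this assay, for the compounds shown here, the aromatic group on the carbon with a double bond to nitrogen proves more influential than the earlier compounds showed, with a 9.9-fold higher number from compound 3 to compound 4 (1.00 log units; beyond the scatter) and an 8.2-fold higher number from compound 1 to compound 4 (0.91 log units; beyond the scatter) both larger than any earlier step. The step of a 3.7-fold higher number from compound 2 to compound 4 (0.57 log units; beyond the scatter) comes from methyl in place of chloro alone, so 4-methylphenyl and 4-chlorophenyl are not interchangeable here. Nothing available explains this difference. Still open, on these data alone, is how an aromatic group carrying an amine or a carboxylic acid would behave. As far as these compounds go, the effect of a longer chain on the amide nitrogen also remains open.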